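Methoxy added to the fluoro anilide: compound 3 ahead

A few compounds are considered here, and "the series" means these few. Any claim that something is new, unique, unknown or untested is made for them only; others in the source may bear on it.

Two compounds of the series carry numbers in a functional assay on A549 cells (Homo sapiens) for cytotoxicity, read by MTT assay, with a stated time of 48 h; on this read-out higher numbers stand for weaker inhibition and lower numbers for stronger inhibition. Compound 1, `COc1cc(C(=O)NC2CCN(C)CC2)ccc1Nc1ncc(Cl)c(NC2CCCC2)n1`, gives 5300 nM in this assay. Compound 2, `CN1CCC(NC(=O)c2ccc(Nc3ncc(F)c(NC4CCCC4)n3)cc2)CC1`, gives 10300 nM in this assay. Compound 2 holds the higher of the two numbers, but the gap to compound 1 lies within the scatter, so the two cannot be ordered against each other on present data.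

Compound 3, `COc1cc(C(=O)NC2CCN(C)CC2)ccc1Nc1ncc(F)c(NC2CCCC2)n1`, awaits measurement in this assay. From compound 2 it differs in one place: methoxy in place of hydrogen on an aromatic carbon. Compound 1 also carries a methoxy group, yet it differs from compound 3 elsewhere as well, so its number only shows that a methoxy-bearing member of the series lands in the same general range as compound 2. Going by the values given here, no recorded step isolates the methoxy change itself.

The step of a 1.6-fold lower number from compound 2 to compound 3 (0.20 log units; within the scatter) is expected to be small, toward a lower number if anything, and not beyond the scatter. Compound 3 is therefore estimated at 6500 nM, with a range from 2500 nM to 16000 nM.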

Compound 3, half-maximal inhibitory concentration: 2100 nM
Compound 3: middle estimate off by 3.1-fold (0.49 log units), on the high side; measured number outside the range, below it.
By their numbers in this assay, from the lowest: compound 3; then compounds 1 and 2 (each within the scatter of the next).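

In this assay, methoxy in place of hydrogen on an aromatic carbon, ortho to a large group and meta to a (1-methylpiperidin-4-yl)carbamoyl group, gives a 4.9-fold lower number from compound 2 to compound 3 (0.69 log units; beyond the scatter). Going by these compounds alone, this is the first reading that isolates this position, and it shows that the position responds to this change on this read-out, with a step beyond the scatter. With the methoxy held constant, the halogen of the shared core also registers, as fluoro in place of chloro on an aromatic carbon gives a 2.5-fold lower number from compound 1 to compound 3 (0.40 log units; beyond the scatter), and no measured evidence on hand bears on the origin of either step.

Whether this response is specific to methoxy remains open, as the compounds shown carry only methoxy or hydrogen at this carbon, with no ethoxy, hydroxyl or amine for comparison. The halogen step is read only in the presence of methoxy, so its size on a core with hydrogen at this carbon also remains open, and the series shown holds only fluoro and chloro at the halogen position, with no bromo or nitrile.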